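Replacing a pyridin-3-yl on the ring nitrogen of compound 1

The source may hold more compounds than are shown below. What is called first, only, known or untested is meant among the compounds shown, and "the series" means these compounds.

Measured so far:
compound 1, `Nc1scc(CN2CCN(c3cccnc3)CC2)c1C(=O)c1ccc(Cl)cc1`, -23%
compound 2, `Nc1scc(CN2CCC(c3ccc(Cl)cc3)CC2)c1C(=O)c1ccc(Cl)cc1`, -61%
compound 3, `Nc1scc(CN2CCN(c3cc(F)cc(F)c3)CC2)c1C(=O)c1ccc(Cl)cc1`, -79%

In a functional assay on CHO cells with adenosine receptor A1 (Homo sapiens) as the target, read by cAMP accumulation and immunoassay, with a stated time of 6 min, tested at 10 uM (a lower number here means a stronger effect, a higher number a weaker effect of the compound at the concentration tested), compound 1 gives the highest of the three numbers. Compound 2 gives -61%, and compound 3 gives -79%, both beyond the scatter away from compound 1. Compound 2 differs from compound 1 in more than one place, so its two values are only shown side by side. Among the compounds with values here, the one step that changes a single place runs a number 56 percentage points lower from compound 1 to compound 3 (beyond the scatter), where a 3,5-difluorophenyl replaces the pyridin-3-yl on an amine nitrogen in a ring.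

Compound 4, `Nc1scc(CN2CCN(c3ccccc3Cl)CC2)c1C(=O)c1ccc(Cl)cc1`, is not yet measured. It differs from compound 1 as follows: 2-chlorophenyl in place of pyridin-3-yl on an amine nitrogen in a ring. Within the data shown here, the change sits at the same amine nitrogen in a ring as the one step, and again a carbon-only aromatic ring replaces the pyridin-3-yl, though with a single chlorine instead of two fluorines. That step was large, so a lower number for compound 4 than for compound 1 is expected, likely beyond the scatter, with the estimated step being a number 37 percentage points lower from compound 1 to compound 4 (beyond the scatter). In this assay compound 4 is therefore estimated at -60%, within a range from -85% to -30%.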

Compound 4, a percentage reported as activity, at one concentration (the size of the read-out at that concentration, not a potency): -18%
For compound 4 the middle estimate is 42 percentage points below the measured one; the measured number lies above the stated range.
By their numbers in this assay, from the lowest: compound 3; then compound 2; then compounds 1 and 4 (each within the scatter of the next).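

In this assay, 2-chlorophenyl in place of pyridin-3-yl on the amine nitrogen in a ring gives a number 5 percentage points higher from compound 1 to compound 4 (within the scatter), which shows that removing the ring nitrogen of pyridin-3-yl and having a carbon-only aromatic ring there is not enough on its own to move the read-out at this position. The large step of a number 61 percentage points higher from compound 3 to compound 4 (beyond the scatter), with 2-chlorophenyl in place of 3,5-difluorophenyl, shows instead that two carbon-only aromatic rings on the same nitrogen can stand far apart, so what matters here is the substitution on the ring and not only the ring's atoms. Nothing measured for these compounds accounts for that gap.

The compounds shown leave open whether the difference between compound 3 and compound 4 follows the kind of halogen, the number of halogens or where they sit on the ring, since all of these change together in that one step. A plain phenyl ring, or one carrying a methoxy group, would be needed to show how much of the read-out belongs to the carbon-only ring itself and how much to what it carries.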